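From tert-butyl to bromo in a cytotoxicity test

The source may hold more compounds than are shown below. What is called first, only, known or untested is meant among the compounds shown, and "the series" means these compounds.

Compound 1 `Cc1cccc(OCCCCCn2ccc(=O)[nH]c2=O)c1` and compound 2 `CC(C)(C)c1ccc(OCCCCCn2ccc(=O)[nH]c2=O)cc1` share the same core and were both tested in an ADME assay on HEL cells (Homo sapiens) for cytotoxicity; on this read-out higher numbers stand for lower toxicity in this test and lower numbers for higher toxicity in this test. Compound 1 gives > 100000 nM, which is a limit of the assay and not a number. Among the compounds with values here, compound 2 gives 40000 nM, the only true number so far, so it is the one fixed point on this scale.

Compound 3 `O=c1ccn(CCCCCOc2ccc(Br)cc2)c(=O)[nH]1` has not yet been measured. It differs from compound 2 in one place: bromo in place of tert-butyl on an aromatic carbon. This puts bromo in place of tert-butyl on an aromatic carbon. Within the data shown here, no measured pair shows this change directly, so the expectation is loose. In this assay, a small step toward lower toxicity is expected a 1.8-fold higher number from compound 2 to compound 3 (0.24 log units; within the scatter), within or near the usual scatter. For compound 3 the estimated value is 70000 nM, expected to fall between 30000 nM and 130000 nM.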

Compound 3, half-maximal cytotoxic concentration: > 100000 nM
Compound 3: only a limit was reported; the forecaster's own chance of this, stated with the estimate: 35%; at least 1.4-fold (0.15 log units) between middle value and limit.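

Within the data shown here, putting bromo in place of tert-butyl on this aromatic carbon gives the first readable step, in this assay: an at least 2.5-fold higher number from compound 2 to compound 3 (0.39 log units; beyond the scatter). Compound 3 gives > 100000 nM, which is a limit of the assay and not a number, so this step is a minimum and moves toward lower toxicity in this test. Its full size stays unknown because the read-out runs out at the top: the limit of > 100000 nM in this assay, at which 2 of the 3 values shown sit.

The step between compound 1 and compound 3 cannot be read, since both values are limits. The compounds shown leave open whether another group at this position, such as an amine or a carboxylic acid, would stay at the limit or bring the number down toward that of compound 2.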